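The source may report more compounds than this note shows. Statements on the series, on what has been measured and on what is new or still open speak of the compounds shown alone.

Compound 2 `CC(=O)n1cc(/C=C(/C(=O)O)c2ccc(Cl)cc2)c2cc(OCc3ccccc3)ccc21` carries an acetyl group on a nitrogen of the shared core, a benzyloxy group, and a 4-chlorophenyl group on a double-bonded chain carbon bound to a carbonyl carbon and a double-bonded chain carbon. In a functional assay on A549 cells (Homo sapiens) for cytotoxicity, read by MTT assay, with a stated time of 72 h (on this read-out higher numbers stand for weaker inhibition and lower numbers for stronger inhibition), compound 2 gives 52300 nM; its nearest neighbour is compound 1 `COc1ccccc1/C(=C\c1cn(C(C)=O)c2ccc(OCc3ccccc3)cc12)C(=O)O`, which in this assay gives 57200 nM. The move a 1.1-fold lower number from compound 1 to compound 2 (0.04 log units; within the scatter) shows that swapping one aryl group for another at this chain carbon left the number essentially where it was.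

Compound 3 `COc1ccc(/C(=C\c2cn(C(C)=O)c3ccc(OCc4ccccc4)cc23)C(=O)O)cc1OC` differs from compound 2 by 3,4-dimethoxyphenyl in place of 4-chlorophenyl on a double-bonded chain carbon bound to a carbonyl carbon and a double-bonded chain carbon. Among the compounds with values here, only the step from compound 1 to compound 2 bears on this kind of change, and it stayed within the scatter, so no movement beyond the scatter is expected in this assay. The expected step from compound 2 to compound 3 is a 1.1-fold higher number from compound 2 to compound 3 (0.02 log units; within the scatter). Compound 3 is therefore estimated at 55000 nM, with a range from 25000 nM to 120000 nM.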

Compound 3, half-maximal inhibitory concentration: 54800 nM
For compound 3 the middle estimate is 1.0-fold (0.00 log units) above the measured one; the measured number falls inside the stated range.
By their numbers in this assay, from the lowest: compounds 2, 3 and 1 (each within the scatter of the next).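

In this assay, the step is a 1.0-fold higher number from compound 2 to compound 3 (0.02 log units; within the scatter) and, against the other aryl group, a 1.0-fold lower number from compound 1 to compound 3 (0.02 log units; within the scatter), so both steps stay within the scatter. Three different aryl groups now sit at this chain carbon without any difference that the assay can resolve. Even 3,4-dimethoxyphenyl, with more heavy atoms than 4-chlorophenyl and with hydrogen-bond acceptors that 4-chlorophenyl lacks, gives a number that cannot be told apart from those of compound 1 and compound 2, and nothing available here offers a reason for this.

All three compounds carry a substituted phenyl ring at this carbon, so these data say nothing about a group of another kind there, such as an amine or a longer alkyl chain. Going by these compounds, it also remains open whether a change elsewhere, for example an amide in place of the carboxylic acid, would move the number beyond the scatter.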